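Mirror images at a limit and an undefined form

The source may report more compounds than this note shows. Statements on the series, on what has been measured and on what is new or still open speak of the compounds shown alone.

In an ADME assay on L929 cells (Mus musculus) for cytotoxicity (a higher number here means a weaker inhibitor, a lower number a stronger inhibitor), compound 1 (`O=[N+]([O-])c1cn2c(n1)[S@@+]([O-])C[C@H](OCc1ccc(OC(F)(F)F)cc1)C2`) gives > 10 ug/mL as its reading, which is a limit and not a number. Its mirror image, compound 2 (`O=[N+]([O-])c1cn2c(n1)[S@+]([O-])C[C@@H](OCc1ccc(OC(F)(F)F)cc1)C2`), gives > 10 ug/mL as its reading, also only a limit. The pair shows a step that the two limits leave unreadable from compound 1 to compound 2 and so offers no measured size. Compound 3 (`O=[N+]([O-])c1cn2c(n1)[S+]([O-])CC(OCc1ccc(OC(F)(F)F)cc1)C2`) differs from compound 2 thus: the two compounds have the same atoms and bonds; at least one stereo element is drawn with a configuration in one of them and without one in the other: 2 of 2 stereo elements differ; a stereocentre at a sulfur is drawn R in compound 2 and without a configuration in compound 3; a stereocentre at a saturated ring carbon is drawn S in compound 2 and without a configuration in compound 3 and nothing more. Going by the values given here, with the fact that compounds 1 and 2 differ only in the configuration as drawn and the limit of > 10 ug/mL in this assay, at which 2 of the 2 values shown sit, as the only guide, no step beyond the scatter is expected, and another limit is likely. The expected change is a step that the limit leaves unreadable from compound 2 to compound 3 in size. Compound 3 is estimated at 20 ug/mL (10 ug/mL to 60 ug/mL) in this assay as its expected reading.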

Compound 3, half-maximal inhibitory concentration in the L929 assay: > 10 ug/mL
Compound 3 gave a limit, no number; the forecaster's own chance of this, stated with the estimate: 85%; the middle value is on the limit's open side.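

In the L929 assay compound 3 gives > 10 ug/mL as its reading, again a limit and not a number. Going by these compounds alone, no step from compound 1 or compound 2 to compound 3 can be read. In the L929 assay the compounds shown leave open whether these three differ at all. In a physicochemical assay for solubility, read by HPLC, measured as kinetic solubility (on this read-out higher numbers stand for higher solubility and lower numbers for lower solubility), compound 2 gives 106 ug/mL and compound 3 gives 39 ug/mL with a 2.7-fold lower number from compound 2 to compound 3 (0.43 log units; beyond the scatter) on this read-out.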